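A few compounds are considered here, and "the series" means these few. Any claim that something is new, unique, unknown or untested is made for them only; others in the source may bear on it.

Going by the values given here, in a functional assay on MOLT-4 cells (Homo sapiens) for cytotoxicity, read by CCK-8 assay, with a stated time of 24 h (a lower number here means a stronger inhibitor, a higher number a weaker inhibitor), compound 1 (`C=CC(=O)N1C(=O)CC(c2ccc(Br)cc2)Sc2ccccc21`) gives 106000 nM and compound 2 (`C=CC(=O)N1C(=O)CC(c2ccccc2)Sc2ccccc21`) gives 85900 nM, so compound 2 stands level with its only measured neighbour. Compound 3 (`C=CC(=O)N1C(=O)CC(c2ccc(C(=O)OC)cc2)Sc2ccccc21`) differs from compound 2 as follows: methoxycarbonyl in place of hydrogen on an aromatic carbon, para to a large group. Among the compounds with values here, the one measured step bearing on this, hydrogen in place of bromo, is a 1.2-fold lower number from compound 1 to compound 2 (0.09 log units; within the scatter). On that single step, no shift beyond the scatter is expected, and the estimated step is a 1.1-fold lower number from compound 2 to compound 3 (0.03 log units; within the scatter). For compound 3 the estimate is 80000 nM, with an expected range of 35000 nM to 170000 nM.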

Compound 3, half-maximal inhibitory concentration: 79600 nM
Beside the measured number, compound 3's estimate is 1.0-fold (0.00 log units) above it, within the range that was stated.
By their numbers in this assay, from the lowest: compounds 3, 2 and 1 (each within the scatter of the next).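

In this assay, methoxycarbonyl on an aromatic carbon, para to a large group, gives a 1.1-fold lower number from compound 2 to compound 3 (0.03 log units; within the scatter) and, set against bromo, a 1.3-fold lower number from compound 1 to compound 3 (0.12 log units; within the scatter). The earlier pair covered only hydrogen and bromo, whereas this change brings in a group of 4 heavy atoms with 2 hydrogen-bond acceptors, and all three compounds still lie within the scatter of one another. No other measurement bears on this result. Going by these compounds, whether an amine or a carboxylic acid at this place would move the number beyond the scatter remains open.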